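The compounds below may be only part of what the source reports. "The series", "measured", "known", "first", "only" and "open" are said of these compounds alone.

Three compounds that share one core and differ in a single group on an aromatic carbon have been tested in a functional assay on HL-60 cells (Homo sapiens) for antiproliferative activity, with a stated time of 72 h; on this read-out higher numbers stand for weaker inhibition and lower numbers for stronger inhibition. Compound 1 (`OC[C@H]1O[C@@H](n2cnc3c(NCc4ccccc4F)ncnc32)[C@H](O)[C@@H]1O`) gives 3200 nM, compound 2 (`OC[C@H]1O[C@@H](n2cnc3c(NCc4ccccc4Br)ncnc32)[C@H](O)[C@@H]1O`) gives 6600 nM, and compound 3 (`COc1ccccc1CNc1ncnc2c1ncn2[C@@H]1O[C@H](CO)[C@@H](O)[C@H]1O`) gives 2300 nM. Compound 3 sits with compound 1 at the low end of these numbers. The gap between those two is a 1.4-fold lower number from compound 1 to compound 3 (0.14 log units; within the scatter), whereas the other comparison is a 2.9-fold lower number from compound 2 to compound 3 (0.46 log units; beyond the scatter).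

Compound 4 (`OC[C@H]1O[C@@H](n2cnc3c(NCc4ccc(F)c(F)c4F)ncnc32)[C@H](O)[C@@H]1O`) has not yet been measured. In it, 2,3,4-trifluorophenyl stands in place of 2-methoxyphenyl on a saturated chain carbon bound to a nitrogen on an aromatic ring: 2,3,4-trifluorophenyl in place of 2-methoxyphenyl on a saturated chain carbon bound to a nitrogen on an aromatic ring. Within the data shown here, the closest precedent, read in reverse, is the exchange between methoxy and fluoro, a 1.4-fold lower number from compound 1 to compound 3 (0.14 log units; within the scatter). Among the measured compounds shown here, the only other halogen exchange is modest, a 2.1-fold higher number from compound 1 to compound 2 (0.31 log units; beyond the scatter). For the measured compounds named here, no measured compound carries the additional fluorines of compound 4, and this leaves the estimate uncertain. A step beyond the scatter is therefore not expected in this assay, although a modest rise remains possible. The estimated change is a 1.5-fold higher number from compound 3 to compound 4 (0.18 log units; within the scatter). For compound 4 the expected value is 3500 nM, with an estimated range from 1500 nM to 8000 nM.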

Compound 4, half-maximal inhibitory concentration: 13000 nM
For compound 4 the middle estimate is 3.7-fold (0.57 log units) below the measured one, outside the stated range (above it).
By their numbers in this assay, from the lowest: compounds 3 and 1 (each within the scatter of the next); then compounds 2 and 4 (each within the scatter of the next).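

In this assay, this position proves not to be indifferent to a fuller change of the ring: among the earlier single-group exchanges, methoxy and fluoro could not be told apart, yet 2,3,4-trifluorophenyl in place of 2-methoxyphenyl gives a 5.7-fold higher number from compound 3 to compound 4 (0.75 log units; beyond the scatter), and keeping a fluorine-bearing ring does not preserve the number either, since 2,3,4-trifluorophenyl in place of 2-fluorophenyl gives a 4.1-fold higher number from compound 1 to compound 4 (0.61 log units; beyond the scatter). Compound 4 instead falls in with the bromo compound, with a 2.0-fold higher number from compound 2 to compound 4 (0.29 log units; within the scatter), so that the high end of these numbers is reached both by a single bromo group and by the trifluorinated ring, and the compounds now form two groups, compounds 1 and 3 at the low end and compounds 2 and 4 at the high end. No measurement at hand speaks to the reason for this separation.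

The compounds shown leave open whether one added fluoro group would already produce the rise or whether all of them are needed, as a 2,3-difluorophenyl or 2,4-difluorophenyl group would tell. They also leave open how an amine or a carboxylic acid on this ring would read in this assay.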